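Urea series: chlorophenyl exchange on the amide nitrogen

The source may report more compounds than this note shows. Statements on the series, on what has been measured and on what is new or still open speak of the compounds shown alone.

Compound 1 `Cc1ccc(NC(=O)NC2CC(C)(C)Oc3ccc(Br)cc32)cc1` carries 4-methylphenyl on the urea nitrogen of the shared core. In a functional assay (aorta) with Rattus norvegicus as the target (a lower number here means that less compound is needed, a higher number that more compound is needed for the effect), compound 1 reaches only the assay limit, > 30000 nM. Compound 2 `CC1(C)CC(NC(=O)Nc2cccc(Cl)c2)c2cc(Br)ccc2O1` differs by 3-chlorophenyl in place of 4-methylphenyl on the amide-type nitrogen. In this assay compound 2 likewise stops at the limit, > 30000 nM. The step that the two limits leave unreadable from compound 1 to compound 2 is therefore of unreadable size and direction, as both measurements sit at the limit of > 30000 nM in this assay, at which 2 of the 2 values shown sit. Compound 3 `CC1(C)CC(NC(=O)Nc2ccc(Cl)cc2)c2cc(Br)ccc2O1`, not yet measured, differs from compound 2 by 4-chlorophenyl in place of 3-chlorophenyl on an amide-type nitrogen. Going by the values given here, no measured step bears on exchanging 3-chlorophenyl for 4-chlorophenyl; the only step available, from compound 1 to compound 2, yields no size. The expected step of a number no higher from compound 2 to compound 3 (the limit leaves the size open) is accordingly none beyond the scatter, with compound 3 anticipated to remain at or near the limit. The estimate for compound 3 in this assay is 30000 nM, within 5000 nM to 100000 nM.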

Compound 3, half-maximal effective concentration: > 300000 nM
Compound 3: no number, only a limit; the forecaster's own chance of this, stated with the estimate: 80%; middle value at least 10-fold (1.00 log units) away from the limit.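

In this assay, going by these compounds alone, compound 3 gives > 300000 nM, again a limit and not a number, so no step among compound 1, compound 2 and compound 3 can be read. The compounds shown leave open whether 4-methylphenyl, 3-chlorophenyl and 4-chlorophenyl on the amide-type nitrogen differ at all in this assay.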